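The compounds below may be only part of what the source reports. "The series", "measured", "known", "first", "only" and "open" are said of these compounds alone.

The study compares four compounds in a functional assay on MCF7 cells (Homo sapiens) for cytotoxicity, read by MTT assay, with a stated time of 72 h; on this read-out higher numbers stand for lower toxicity in this test and lower numbers for higher toxicity in this test. Compound 1 `CS/C(=N\C(=O)c1ccno1)NC(=O)c1ccno1`, compound 2 `O=C(/N=C(/NC(=O)c1ccno1)[Se]Cc1ccccc1)c1ccno1` and compound 3 `O=C(/N=C(/NC(=O)c1cccs1)[Se]Cc1ccccc1)c1cccs1` have been measured, while compound 4 `CS/C(=N\C(=O)c1cccs1)NC(=O)c1cccs1` has not. In this assay compound 1 gives > 100000 nM, which is a limit of the assay and not a number. In this assay compound 2 gives > 100000 nM, again only a limit. In this assay compound 3 gives > 100000 nM, also a limit. From compound 2 to compound 1 the change is a group of 2 heavy atoms (1 carbon, 1 sulfur; no ring) in place of a group of 8 heavy atoms (7 carbon, 1 selenium; one six-membered aromatic ring of carbon only), on a carbon with a double bond to nitrogen and the step it made is a step that the two limits leave unreadable from compound 2 to compound 1, unreadable because of the limit of > 100000 nM in this assay, at which 3 of the 3 values shown sit. Compound 3 and compound 2 differ in their cores, and that difference is not broken down here. From compound 3 to compound 4 the change is a group of 2 heavy atoms (1 carbon, 1 sulfur; no ring) in place of a group of 8 heavy atoms (7 carbon, 1 selenium; one six-membered aromatic ring of carbon only), on a carbon with a double bond to nitrogen, the same change as from compound 2 to compound 1, at a place described in the same words. Compound 4 is therefore expected to stay at the limit as well, with an estimate of 100000 nM and a range from 50000 nM to 300000 nM. The expected step is a number no higher from compound 3 to compound 4 (the limit leaves the size open) and rests on a step that the two limits leave unreadable from compound 2 to compound 1.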

Compound 4, concentration lethal to 50% of the cells: > 100000 nM
Compound 4: a limit, no number (the forecaster's own chance of this, stated with the estimate: 85%); the middle value sits exactly at the limit.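

No new step can be read from compound 3 to compound 4 in this assay, and the same holds for compound 2 and compound 1, because all four compounds give only a limit of the assay and not a number: the limit of > 100000 nM in this assay, at which 4 of the 4 values shown sit. The compounds shown leave open how the methylsulfanyl group and the group it replaces compare in toxicity in this test, and how the two cores compare.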